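The source may report more compounds than this note shows. Statements on the series, on what has been measured and on what is new or still open speak of the compounds shown alone.

Measured so far:
Compound 1 `C=C[C@@](C)(/C=C/c1ccc(O)c(/C=C/C#N)c1)CCC=C(C)C`: > 36600 nM, a limit
Compound 2 `C=C[C@@](C)(/C=C/c1ccc(O)c(/C=C(\C)C(=O)OCC)c1)CCC=C(C)C`: > 36600 nM, a limit
Compound 3 `COc1ccc(/C=C/[C@@](C)(/C=C/c2ccc(O)c(/C=C/C#N)c2)CCC=C(C)C)cc1`: > 23700 nM, a limit

All three results in an ADME assay on BJ cells (Homo sapiens) for cytotoxicity, with a stated time of 72 h (a higher number here means that more compound is needed for the effect, a lower number that less compound is needed), are limits of the assay, not numbers. Compound 3 stands at the limit of > 23700 nM in this assay, at which 1 of the 3 values shown sits. Compound 1 and compound 2 stand at the limit of > 36600 nM in this assay, at which 2 of the 3 values shown sit.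

The next compound is compound 4 `CCOC(=O)/C(C)=C/c1cc(/C=C/[C@](C)(/C=C/c2ccc(OC)cc2)CCC=C(C)C)ccc1O`, which differs from compound 3 by one exchange: 2-(ethoxycarbonyl)prop-1-en-1-yl in place of 2-cyanoethenyl on an aromatic carbon. It puts 2-(ethoxycarbonyl)prop-1-en-1-yl in place of 2-cyanoethenyl on an aromatic carbon, ortho to a hydroxy group.

The same exchange has been measured once, on the core of compound 1, as a step that the two limits leave unreadable from compound 1 to compound 2. The other measured step, a step that the two limits leave unreadable from compound 1 to compound 3, introduced the 2-(4-methoxyphenyl)ethenyl group that compound 4 retains. Neither step has a readable size, so neither indicates a direction, and no change beyond the scatter is expected in this assay. The expected result is a step that the limit leaves unreadable from compound 3 to compound 4. The estimate for compound 4 is 25000 nM, with an expected range from 10000 nM to 40000 nM.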

Compound 4, half-maximal effective concentration: > 36600 nM
Compound 4: only a limit was reported; the forecaster's own chance of this, stated with the estimate: 85%; middle value at least 1.4-fold (0.16 log units) away from the limit.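

Compound 4 also gives only a limit, so neither the step from compound 3 to compound 4 nor the step from compound 2 to compound 4 can be read. The compounds shown leave open whether either exchange changes the result in this assay at all.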